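Urea to Plain Benzamide: Expected Loss of Growth Inhibition

A few compounds are considered here, and "the series" means these few. Any claim that something is new, unique, unknown or untested is made for them only; others in the source may bear on it.

Compound 1 `COc1cc(-c2nn(-c3cccc(NC(=O)Nc4cccc(C(F)(F)F)c4)c3)cc2-c2ccncc2)ccc1Cl`: 1870 nM
Compound 2 `COc1cc(-c2nn(-c3cccc(NC(=O)c4ccc(Cl)c(C(F)(F)F)c4)c3)cc2-c2ccncc2)ccc1Cl`: 19800 nM
Compound 3 `COc1cc(-c2nn(-c3cccc(NC(=O)Nc4ccc(Cl)c(C(F)(F)F)c4)c3)cc2-c2ccncc2)ccc1Cl`: 2440 nM

In a functional assay on OVCAR-3 cells (Homo sapiens) for inhibition, read by sulforhodamine B assay, with a stated time of 48 h (on this read-out lower numbers stand for stronger inhibition of growth and higher numbers for weaker inhibition of growth), compound 3 gives the second highest of the three numbers. It lies nearest to compound 1, with a 1.3-fold higher number from compound 1 to compound 3 (0.12 log units; within the scatter), and furthest from compound 2, with an 8.1-fold lower number from compound 2 to compound 3 (0.91 log units; beyond the scatter). Compound 4 `COc1cc(-c2nn(-c3cccc(NC(=O)c4ccccc4)c3)cc2-c2ccncc2)ccc1Cl` differs from compound 3 in one place: phenyl in place of (4-chloro-3-(trifluoromethyl)phenyl)amino on a carbonyl carbon. Among the measured compounds shown here, the only measured step bearing on this change is the amide-to-urea exchange, an 8.1-fold lower number from compound 2 to compound 3 (0.91 log units; beyond the scatter), which ran beyond the scatter; compound 4 reverses it and also drops the chloro and trifluoromethyl groups, a loss for which no measured pair exists. A clearly weaker result in this assay is therefore expected for compound 4, a 12-fold higher number from compound 3 to compound 4 (1.09 log units; beyond the scatter), estimated at 30000 nM within a range of 10000 nM to 100000 nM.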

Compound 4, concentration for total growth inhibition: 10900 nM
Compound 4: middle estimate off by 2.8-fold (0.44 log units), on the high side; measured number inside the range.
By their numbers in this assay, from the lowest: compounds 1 and 3 (each within the scatter of the next); then compounds 4 and 2 (each within the scatter of the next).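

At this carbonyl carbon, plain phenyl gives weaker growth inhibition than either urea in this assay, with a 4.5-fold higher number from compound 3 to compound 4 (0.65 log units; beyond the scatter) and a 5.8-fold higher number from compound 1 to compound 4 (0.77 log units; beyond the scatter) on the two urea comparisons. Among the amides, a 1.8-fold lower number from compound 2 to compound 4 (0.26 log units; within the scatter) shows that the chloro and trifluoromethyl groups on the benzamide ring bring no gain beyond the scatter, so in these compounds the lower numbers go with the urea linkage rather than with those ring groups. No evidence here explains the link between the urea and stronger inhibition. Also open, going by these compounds, is how an unsubstituted phenyl urea, or a benzamide ring carrying an amine or a carboxylic acid, would read.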